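The compounds below may be only part of what the source reports. "The series", "measured", "known", "first", "only" and "open" are said of these compounds alone.

Measured compounds:
compound 1 `O=C1NC(=O)/C(=C/C2=Cc3ccccc3OC2)S1` gives 98900 nM
compound 2 `O=C1NC(=S)S/C1=C\C1=Cc2ccccc2OC1` gives 55300 nM

Both compounds were tested in a functional assay on K562 cells (Homo sapiens) for antiproliferative activity, read by MTT assay, with a stated time of 72 h; on this read-out lower numbers stand for stronger inhibition and higher numbers for weaker inhibition. Compound 1 holds the highest of the two numbers, but its nearest neighbour, compound 2, sits within the usual scatter of it, so the two cannot be told apart. What the two values show is that both compounds act only weakly in this assay.

Compound 3 `CCN1C(=O)S/C(=C\C2=Cc3ccccc3OC2)C1=O` has not been measured. It differs from compound 1 in one place: ethyl in place of hydrogen on an amide-type nitrogen in a ring. For the measured compounds named here, no step between measured compounds bears on this change, so the account rests on the two values alone and on the size of the structural change, which is small. Compound 3 is expected to stay close to compound 1 in this assay, with the step of a 1.2-fold lower number from compound 1 to compound 3 (0.09 log units; within the scatter) estimated to lie within the scatter rather than beyond it in either direction. For compound 3 the estimate in this assay is 80000 nM, with a range from 25000 nM to 250000 nM.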

Compound 3, half-maximal inhibitory concentration: > 200000 nM
Compound 3 ended at the assay's limit; the forecaster's own chance of this, stated with the estimate: 20%; middle value at least 2.5-fold (0.39 log units) away from the limit.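

In this assay compound 3 gives > 200000 nM, and this value is a limit of the assay, not a number. The step that can be read is an at least 2.0-fold higher number from compound 1 to compound 3 (0.30 log units; that floor lies within the scatter), so the amide-type nitrogen in the ring, on which no measured comparison bore before, now has one: ethyl in place of hydrogen at this position brings no gain in inhibition, and the reading points towards weaker inhibition, although the floor of the step does not by itself go beyond the scatter. How far the true value of compound 3 lies past the limit stays unknown, and the size of the step is capped in what it can tell by the end of the assay's range: the limit of > 200000 nM in this assay, at which 1 of the 3 values shown sits.

The compounds shown leave open whether the change in reading follows from losing the amide hydrogen or from the ethyl group itself, and how a methyl group, a longer chain or a chain ending in a carboxylic acid or an amine on this nitrogen would read in this assay. They also leave open whether the same ethyl change would read alike on compound 2.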